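Compound 3 at the limit, compound 4 awaited

This account rests on a few compounds, and the source may have more. Where it says the series, first, only, none or still open, it means among the compounds named here.

Measured in a functional assay on HT-29 cells (Homo sapiens) for inhibition, read by MTT assay, with a stated time of 120 h; a lower number here means a stronger inhibitor, a higher number a weaker inhibitor:
Compound 1 `O=C(/C=C/c1ccc(NC(=O)Nc2ccc(Cl)c(C(F)(F)F)c2)cc1)NC1CCC1`: 4430 nM
Compound 2 `CC(NC(=O)C#Cc1ccc(NC(=O)Nc2ccc(Cl)c(C(F)(F)F)c2)cc1)c1ccccc1`: 4920 nM
Compound 3 `CNC(=O)/C=C(\C)c1ccc(NC(=O)Nc2ccc(Cl)c(C(F)(F)F)c2)cc1`: > 50000 nM (a limit, not a number)

Compound 3 has no exact value, only (the limit of > 50000 nM in this assay, at which 1 of the 3 values shown sits). Going by the values given here, the one measured step that bears on it is an at least 11-fold higher number from compound 1 to compound 3 (1.05 log units; beyond the scatter), which is large and beyond the scatter. The next structure, compound 4 `CNC(=O)C#Cc1ccc(NC(=O)Nc2ccc(Cl)c(C(F)(F)F)c2)cc1`, differs from compound 3 as follows: 2-(methylcarbamoyl)ethynyl in place of 1-methyl-2-(methylcarbamoyl)ethenyl on an aromatic carbon. The 2-(methylcarbamoyl)ethynyl group thus takes the place of 1-methyl-2-(methylcarbamoyl)ethenyl on an aromatic carbon, para to a large group. Among the compounds with values here, no measured step covers this exact change. Compound 2, which also has a triple bond in this chain, gives 4920 nM, and this points to a lower number for compound 4. However, compound 2 has a different amide group, so only a partial recovery is assumed. In this assay the estimated step is an at least 4.1-fold lower number from compound 3 to compound 4 (0.61 log units; beyond the scatter), toward a lower number, with its size uncertain since the starting point is only a limit. Compound 4 is expected at 12000 nM, with an estimated range from 3500 nM to 45000 nM.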

Compound 4, half-maximal inhibitory concentration: 14000 nM
For compound 4 the middle estimate is 1.2-fold (0.07 log units) below the measured one, and the stated range covers the measured number.
By their numbers in this assay, from the lowest: compounds 1 and 2 (each within the scatter of the next); then compound 4. At a limit, above all of these: compound 3.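

Compound 3 is held only at a limit in this assay, not at a number: the limit of > 50000 nM in this assay, at which 1 of the 4 values shown sits.

Putting 2-(methylcarbamoyl)ethynyl in place of 1-methyl-2-(methylcarbamoyl)ethenyl on this aromatic carbon, para to a large group, brings back a measurable value, with an at least 3.5-fold lower number from compound 3 to compound 4 (0.55 log units; beyond the scatter). The group on the amide nitrogen also matters when the triple bond is kept: methyl in place of 1-phenylethyl gives a 2.8-fold higher number from compound 2 to compound 4 (0.45 log units; beyond the scatter), while a 3.2-fold higher number from compound 1 to compound 4 (0.50 log units; beyond the scatter) changes the chain and the amide group together, so it cannot separate the two.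

As far as these compounds go, it remains open whether the gain at this position comes from the triple bond or from the loss of the 1-methyl group. Also open, from the compounds shown here alone, is how a carboxylic acid or a longer chain in place of this amide would read in this assay.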